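The source may report more compounds than this note shows. Statements on the series, on what has been measured and on what is new or still open speak of the compounds shown alone.

The series shares one core, carried by compound 1 `Cc1nc(C#Cc2ccccc2)cs1`, compound 2 `Cc1nc(C#Cc2cncc(-c3ccccc3)c2)cs1` and compound 3 `Cc1nc(C#Cc2cncc(-c3cccnc3)c2)cs1`. In a functional assay for agonist activity at metabotropic glutamate receptor 5 (Homo sapiens) (a lower number here means a stronger inhibitor, a higher number a weaker inhibitor), compound 1 gives 4 nM, compound 2 gives 2 nM and compound 3 gives 3 nM. On these numbers compound 3 stands second highest of the three; its nearest neighbour is compound 1 and its furthest is compound 2, and both gaps lie within the scatter, so the three cannot be placed in any firm order. Among the compounds with values here, the one step available, a 1.5-fold higher number from compound 2 to compound 3 (0.18 log units; within the scatter), exchanged phenyl for pyridin-3-yl and stayed within the scatter.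

Compound 4 `Cc1nc(C#Cc2cncc(-c3ccncc3)c2)cs1` has not yet been measured in this assay. It differs from compound 3 by pyridin-4-yl in place of pyridin-3-yl on an aromatic carbon. Within the data shown here, no measured pair shows exactly this exchange; the only step that bears on it is a 1.5-fold higher number from compound 2 to compound 3 (0.18 log units; within the scatter), which changed the same outer ring without an effect beyond the scatter. Because a 1.5-fold higher number from compound 2 to compound 3 (0.18 log units; within the scatter) left the number essentially unmoved, the step of no change at the digits printed from compound 3 to compound 4 (within the scatter) is expected to stay within the scatter, in no particular direction. Compound 4 is therefore estimated at 3 nM in this assay, within a range from 1.5 nM to 7 nM.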

Compound 4, half-maximal inhibitory concentration: 18 nM
Compound 4: middle estimate off by 6.0-fold (0.78 log units), on the low side, and the stated range ends below it.
By their numbers in this assay, from the lowest: compounds 2, 3 and 1 (each within the scatter of the next); then compound 4.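

Within the data shown here, the result is the first sign that this position responds to the outer ring in this assay: moving the ring nitrogen alone gives a 6.0-fold higher number from compound 3 to compound 4 (0.78 log units; beyond the scatter), although pyridin-3-yl and pyridin-4-yl have the same counts of heavy atoms and hydrogen-bond acceptors and neither carries a net charge. Set against phenyl, pyridin-4-yl gives a 9.0-fold higher number from compound 2 to compound 4 (0.95 log units; beyond the scatter), while pyridin-3-yl gave only a 1.5-fold higher number from compound 2 to compound 3 (0.18 log units; within the scatter), so across these three compounds a ring nitrogen as such does not separate the outer rings, but its place in the ring does. The compounds shown offer no measurement that accounts for this loss of inhibitory strength.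

Going by these compounds, it remains open whether pyridin-2-yl, the third placement of the ring nitrogen, would stay close to compound 2 and compound 3 or move towards compound 4. On these data alone, it is equally open how a phenyl ring carrying a methoxy group, a nitrile or an amine would behave at this position, and whether the effect of the pyridin-4-yl group would hold on any other core.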